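Replacing a Sulfonamide Chain with a Lactam-Bearing Piperidine

The compounds below may be only part of what the source reports. "The series", "measured", "known", "first", "only" and "open" are said of these compounds alone.

Compound 1, `Cc1nc(N2CCC(N3CCOC3=O)CC2)nc2ccc(NC(=O)/C=C/c3ccc(OC(F)(F)F)cc3)cc12`: 31 nM
Compound 2, `Cc1nc(NCCNC(=O)C2CC2)nc2ccc(NC(=O)/C=C/c3ccc(OC(F)(F)F)cc3)cc12`: 23 nM
Compound 3, `Cc1nc(NCCNS(C)(=O)=O)nc2ccc(NC(=O)/C=C/c3ccc(OC(F)(F)F)cc3)cc12`: 142 nM

All three compounds share one core and were tested in a functional assay on CHO-K1 cells for antagonist activity at melanin-concentrating hormone receptor 1 (Homo sapiens), read by inositol phosphate accumulation, with stated times of 10 min and 45 min; a lower number here means a stronger inhibitor, a higher number a weaker inhibitor. Compound 3 gives the highest number of the three: the step of a 4.6-fold higher number from compound 1 to compound 3 (0.66 log units; beyond the scatter) and the step of a 6.2-fold higher number from compound 2 to compound 3 (0.79 log units; beyond the scatter) both lie beyond the scatter, so compound 3 is the weakest inhibitor in this set. Compound 4, `Cc1nc(N2CCC(N3CCCC3=O)CC2)nc2ccc(NC(=O)/C=C/c3ccc(OC(F)(F)F)cc3)cc12`, has not been measured yet. It differs from compound 3 in one place: 4-(2-oxopyrrolidin-1-yl)piperidin-1-yl in place of (2-(methanesulfonamido)ethyl)amino on an aromatic carbon. The closest guide is compound 1, which carries a piperidine bearing a five-membered ring with a carbonyl at the same aromatic carbon, and which differs from compound 4 only in the ring of that lactam. The step of a 4.6-fold higher number from compound 1 to compound 3 (0.66 log units; beyond the scatter) shows how much was lost on moving to the sulfonamide chain, and the reverse move is expected to recover about that amount, so the expected step is a 4.7-fold lower number from compound 3 to compound 4 (0.68 log units; beyond the scatter). Compound 4 is therefore estimated at 30 nM, in a range from 12 nM to 75 nM.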

Compound 4, half-maximal inhibitory concentration: 12 nM
The estimate for compound 4 lay 2.5-fold (0.40 log units) above the measured number; low and high end bracket the measured number.
By their numbers in this assay, from the lowest: compounds 4, 2 and 1 (each within the scatter of the next, the first and the last beyond it); then compound 3.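

Of the changes at this aromatic carbon, the step of a 12-fold lower number from compound 3 to compound 4 (1.07 log units; beyond the scatter) is the largest seen so far in this assay. The lactam ring on the piperidine also counts, as 2-oxopyrrolidin-1-yl in place of 2-oxo-1,3-oxazolidin-3-yl gives a 2.6-fold lower number from compound 1 to compound 4 (0.41 log units; beyond the scatter) with the rest of the molecule unchanged. An open chain is not poor in itself, however: the step of a 1.9-fold lower number from compound 2 to compound 4 (0.28 log units; within the scatter) puts the cyclopropylcarbonyl chain and the new piperidine level, so the weak result of compound 3 goes with its methanesulfonamide chain and not with having a chain at all.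

Nothing at hand explains why these changes act as they do. Also open, as far as these compounds go, is how a six-membered lactam, or a simple amine or carboxylic acid in place of the lactam on the piperidine, would fare in this assay at this position.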